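The compounds below may be only part of what the source reports. "The series", "measured", "known", "first", "only" and "open" are said of these compounds alone.

Measured so far in an assay on HEK293 cells for inhibition of Voltage-dependent T-type calcium channel subunit alpha-1G (Homo sapiens), read by fluorescence, tested at 10 uM; on this read-out lower numbers stand for less inhibition and higher numbers for more inhibition at the one concentration tested (going by the name of the read-out):
compound 1 `CCCc1nc(-c2ccccc2)c(CNCCCN2CCN(c3cccc(C)c3)CC2)o1` gives 47.8%;
compound 2 `CCCc1nc(-c2ccccc2)c(CNCCN2CCN(c3cccc(C)c3C)CC2)o1` gives 66.7%;
compound 3 `CCCc1nc(-c2ccccc2)c(CNCCN2CCN(c3ccccc3C)CC2)o1` gives 51.3%.

Compound 1 stands lowest of the three numbers in this assay. Its nearest neighbour is compound 3, whose number is higher by an amount that lies within the usual scatter, so the two cannot be told apart. Compound 2 lies furthest away, beyond the scatter. Among the measured compounds shown here, the one measured step, a number 15.4 percentage points lower from compound 2 to compound 3 (beyond the scatter), shows that removing a methyl group from an aromatic carbon lowered the number by a modest amount.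

Compound 4 `CCCc1nc(-c2ccccc2)c(CNCCCN2CCN(c3cccc(F)c3)CC2)o1` differs from compound 1 by fluoro in place of methyl on an aromatic carbon, which one bond further out reads 3-methylphenyl to 3-fluorophenyl. For the measured compounds named here, no measured step swaps methyl for fluoro on the shared core, so the step of a number 15.4 percentage points lower from compound 2 to compound 3 (beyond the scatter) bears only loosely on it: it suggests that losing the methyl may cost something, while fluoro is a group for which the data show nothing. The expected step of a number 5.8 percentage points lower from compound 1 to compound 4 (within the scatter) is therefore small, at most a modest lowering, and may fall within the scatter. Compound 4 is estimated at 42%, with a range from 25% to 60%.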

Compound 4, a percentage reported as inhibition, at one concentration (the size of the read-out at that concentration, not a potency): 68.9%
The estimate for compound 4 lay 26.9 percentage points below the measured number; measured number outside the range, above it.
By their numbers in this assay, from the lowest: compounds 1 and 3 (each within the scatter of the next); then compounds 2 and 4 (each within the scatter of the next).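

In this assay, the swap from 3-methylphenyl to 3-fluorophenyl gives a number 21.1 percentage points higher from compound 1 to compound 4 (beyond the scatter), so on this chain the number depends on which group is held there. The earlier step, a number 15.4 percentage points lower from compound 2 to compound 3 (beyond the scatter), showed only the loss of a methyl and said nothing about fluoro. Nothing at hand explains this rise.

From the compounds shown here alone, whether chloro or methoxy at this place would give a number closer to that of compound 4 or to that of compound 1 remains open. So does whether fluoro would have the same effect on the chain of compound 2.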